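A few compounds are considered here, and "the series" means these few. Any claim that something is new, unique, unknown or untested is made for them only; others in the source may bear on it.

The series is followed in a functional assay on NCI-H23 cells (Homo sapiens) for cytotoxicity, read by sulforhodamine B assay, with a stated time of 72 h; a higher number here means a weaker inhibitor of growth, a lower number a stronger inhibitor of growth. Compound 1 `O=C(Nc1ccccc1C(F)(F)F)C1CCc2ccccc2N1` gives 56800 nM there. Compound 2 `CCC(=O)N1c2ccccc2CCC1C(=O)Nc1ccccc1C(F)(F)F` returns only > 80000 nM, which is a limit of the assay and not a number. Compound 3 `CCC(=O)N1c2ccccc2CCC1C(=O)Nc1cc(C(F)(F)F)cc(C(F)(F)F)c1` gives 7820 nM, the lowest of the two numbers, with compound 1 the nearest and that gap beyond the scatter.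

The change from compound 2 to compound 1 is hydrogen in place of propanoyl on a nitrogen on an aromatic ring in a ring. It brought an at least 1.4-fold lower number from compound 2 to compound 1 (0.14 log units; that floor lies within the scatter), and only a floor can be given because one of the two values sits at the limit of > 80000 nM in this assay, at which 1 of the 3 values shown sits. Compound 4 `O=C(Nc1cc(C(F)(F)F)cc(C(F)(F)F)c1)C1CCc2ccccc2N1` carries the same change relative to compound 3, (hydrogen in place of propanoyl on a nitrogen on an aromatic ring in a ring), at a place described in identical words, so this is the same change on a different core; how the core of compound 3 differs from that of compound 2 is not broken down here.

The step expected from compound 3 to compound 4 is a 1.4-fold lower number from compound 3 to compound 4 (0.15 log units; within the scatter), set beside the earlier at least 1.4-fold lower number from compound 2 to compound 1 (0.14 log units; that floor lies within the scatter), and it rests on that earlier step alone. Compound 4 is therefore estimated at 5500 nM, with a range from 1800 nM to 17000 nM.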

Compound 4, concentration for 50% growth inhibition: 8410 nM
Estimate against measurement, compound 4: 1.5-fold (0.18 log units) below; low and high end bracket the measured number.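

In this assay, hydrogen in place of propanoyl on a nitrogen on an aromatic ring in a ring gives a 1.1-fold higher number from compound 3 to compound 4 (0.03 log units; within the scatter), so on this core the change leaves no difference that can be read. Set beside the earlier step, the result on the two cores reads: the same change on two cores in this assay, an at least 1.4-fold lower number (0.14 log units; that floor lies within the scatter) from compound 2 to compound 1 and a 1.1-fold higher number (0.03 log units; within the scatter) from compound 3 to compound 4; the limit leaves it open whether they differ. This shows that the change can be carried to the core of compound 3 without a step beyond the scatter, but it does not show that the change behaves alike on both cores, because compound 2 gives a limit and not a number: the limit of > 80000 nM in this assay, at which 1 of the 4 values shown sits.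

As far as these compounds go, it remains open whether an acetyl group, a longer acyl chain, an amine or a carboxylic acid at the same nitrogen would give a similar result. From the compounds shown here alone, it also remains open whether the comparison would hold on cores carrying a nitrile or a chlorine in place of trifluoromethyl.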